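Methyl Removal on the Core of Compound 1

The source may hold more compounds than are shown below. What is called first, only, known or untested is meant among the compounds shown, and "the series" means these compounds.

Compound 1 `Cc1c(C(=O)NCc2cccc(C(F)(F)F)c2)cnn1-c1ccc(Cl)c(Cl)c1` is the reference point of this pair. In a functional assay on cells for antagonist activity at C-C chemokine receptor type 1 (Homo sapiens), read by FLIPR and calcium flux (on this read-out higher numbers stand for weaker inhibition and lower numbers for stronger inhibition), compound 1 gives 500 nM. Within the data shown here, its only measured neighbour is compound 2 `Cc1c(C(=O)NCc2cccc(C(F)(F)F)c2)cnn1-c1ccc(Cl)cc1`, which in this assay gives 600 nM; the step of a 1.2-fold higher number from compound 1 to compound 2 (0.08 log units; within the scatter) shows that the two compounds sit within the scatter of each other, so neither can be ranked against the other. Compound 3 `O=C(NCc1cccc(C(F)(F)F)c1)c1cnn(-c2ccc(Cl)c(Cl)c2)c1` is not yet measured. Relative to compound 1 the change is hydrogen in place of methyl on an aromatic carbon. Among the measured compounds shown here, no measured step touches this methyl: the one step in hand, a 1.2-fold higher number from compound 1 to compound 2 (0.08 log units; within the scatter), concerns a chloro on the 3,4-dichlorophenyl group, and it stayed within the scatter. It therefore offers no direct guide to the methyl and gives no reason to expect a large shift in either direction; the series has tolerated one small loss without effect. Compound 3 is expected near 800 nM, with a likely range from 300 nM to 2500 nM, corresponding to an estimated step of a 1.6-fold higher number from compound 1 to compound 3 (0.20 log units; within the scatter).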

Compound 3, half-maximal inhibitory concentration: > 3000 nM
Compound 3: no number, only a limit (the forecaster's own chance of this, stated with the estimate: 5%); middle value at least 3.7-fold (0.57 log units) away from the limit.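

The methyl on the aromatic carbon next to the ring atom that bears a 3,4-dichlorophenyl group counts for much more in this assay than its single heavy atom might suggest: hydrogen in its place gives an at least 6.0-fold higher number from compound 1 to compound 3 (0.77 log units; beyond the scatter). The chloro change on the same compound gives only a 1.2-fold higher number from compound 1 to compound 2 (0.08 log units; within the scatter), so the methyl change is the only step shown that lies beyond the scatter, and the tolerance seen for that chloro does not extend to this position. Compound 3 gives > 3000 nM, which is a limit of the assay and not a number, so the size of the methyl step is a lower bound only: the limit of > 3000 nM in this assay, at which 1 of the 3 values shown sits.

The compounds shown leave open whether an ethyl, a chloro or a methoxy group on this carbon would match or improve on the methyl of compound 1, and so whether the position favours the methyl itself or any group larger than hydrogen. Also open, on these data alone, is whether the same change would cost as much with the 4-chlorophenyl group of compound 2.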